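Aryl sulfonamide series: phenyl for amino on the sulfonyl aryl

The source may hold more compounds than are shown below. What is called first, only, known or untested is meant among the compounds shown, and "the series" means these compounds.

For the measured compounds named here, compound 1, with the structure `CC1CCN(C2CCN(S(=O)(=O)c3cccc(N)c3)CC2)CC1`, is the only member of the series with a numerical value: in a functional assay on DLD-1 cells (Homo sapiens) for antiproliferative activity, read by CellTiter-Glo, with a stated time of 72 h (on this read-out lower numbers stand for stronger inhibition and higher numbers for weaker inhibition), compound 1 gives 3400 nM. Compound 2 `CC1CCN(C2CCN(S(=O)(=O)c3cccnc3F)CC2)CC1` reaches only a limit of the assay, > 5000 nM. Compound 3 `CC1CCN(C2CCN(S(=O)(=O)c3cncc(Br)c3)CC2)CC1` likewise sits at a limit, > 5000 nM. Both steps away from compound 1 read as limits: an at least 1.4-fold higher number from compound 1 to compound 2 (0.16 log units; that floor lies within the scatter), and an at least 1.4-fold higher number from compound 1 to compound 3 (0.16 log units; that floor lies within the scatter); the pair of limits leaves a step that the two limits leave unreadable from compound 2 to compound 3. Going by the values given here, the only evidence on the measured steps is the limit of > 5000 nM in this assay, at which 2 of the 3 values shown sit.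

Compound 4 `CC1CCN(C2CCN(S(=O)(=O)c3cccc(-c4ccccc4)c3)CC2)CC1` is not yet measured. It differs from compound 1 by phenyl in place of amino on an aromatic carbon, on the aromatic carbon meta to a large group. Among the compounds with values here, no measured step exchanges amino for phenyl; the two known steps swap the whole 3-aminophenyl for a pyridinyl and both run to weaker numbers. Only a weak or no step beyond the scatter is therefore expected, with a real chance of another limit. Compound 4 is estimated at 4000 nM, between 1500 nM and 12000 nM, which means an expected step of a 1.2-fold higher number from compound 1 to compound 4 (0.07 log units; within the scatter).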

Compound 4, half-maximal inhibitory concentration: 2 nM
Beside the measured number, compound 4's estimate is 2000-fold (3.30 log units) above it, outside the stated range (below it).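

Phenyl in place of amino, on an aromatic carbon meta to a large group, gives a 1700-fold lower number from compound 1 to compound 4 (3.23 log units; beyond the scatter) in this assay. This place on the sulfonyl aryl therefore responds very strongly to what it carries, which compound 1, compound 2 and compound 3 gave no sign of. Those earlier compounds could not reveal such a range, because their comparison stops at the edge of what the assay reports: the limit of > 5000 nM in this assay, at which 2 of the 4 values shown sit.

Compound 4 alone does not tell whether an aromatic ring is needed at this place, or whether a saturated ring such as cyclohexyl or a small group such as methyl would serve as well. On these data alone, it also remains open whether a fluorine or a methoxy group on the new phenyl would keep, lower or raise the number.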